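Ethoxy to dimethylcarbamoyl: working notes on compound 3

This account rests on a few compounds, and the source may have more. Where it says the series, first, only, none or still open, it means among the compounds named here.

In a functional assay for inhibition, with Homo sapiens as the target (on this read-out higher numbers stand for weaker inhibition and lower numbers for stronger inhibition), compound 1 (`COc1cccc(C(=O)/C=C/c2ccccc2)c1OC`) gives 1670 nM as its reading. Compound 2 (`COc1cccc(OC)c1C(=O)/C=C/c1ccccc1`) gives 1150 nM on the same read-out. Compound 3 (`CCOc1ccccc1C(=O)/C=C/c1ccccc1`) gives 609 nM and sits within the scatter of compound 2, while compound 1 carries a higher number than compound 3 by a gap beyond the scatter. The three readings therefore lie close together, and compound 3 belongs to the low end of that narrow set.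

The next compound to be read is compound 4 (`CN(C)C(=O)c1ccccc1C(=O)/C=C/c1ccccc1`). The change from compound 3 is dimethylcarbamoyl in place of ethoxy on an aromatic carbon in short: dimethylcarbamoyl in place of ethoxy on an aromatic carbon, ortho to a large group.

Among the compounds with values here, no measured pair differs in one place only, and no measured compound carries dimethylcarbamoyl, so the series offers no direct precedent. The other readings in hand are compound 2 at 1150 nM and compound 1 at 1670 nM so a new group is expected to land nearer those numbers or somewhat past them. The expected move is a 3.0-fold higher number from compound 3 to compound 4 (0.47 log units; beyond the scatter) toward weaker inhibition, modest in size and a little beyond the scatter. The estimate for compound 4 is 1800 nM with an expected range from 600 nM to 7000 nM on this read-out.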

Compound 4, half-maximal inhibitory concentration: 5500 nM
Compound 4: the middle estimate sits 3.1-fold (0.49 log units) below what was measured, and the stated range covers the measured number.
By their numbers in this assay, from the lowest: compounds 3, 2 and 1 (each within the scatter of the next, the first and the last beyond it); then compound 4.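

In this assay, within the data shown here, dimethylcarbamoyl in place of ethoxy on an aromatic carbon, ortho to a large group, gives a 9.0-fold higher number from compound 3 to compound 4 (0.96 log units; beyond the scatter) and is the only step that changes a single place. It shows that this position does not tolerate every group equally, since the reading moves toward weaker inhibition even though the hydrogen-bond donor and acceptor counts stay the same, neither group carries a net charge, and the heavy-atom count of the group rises only from 3 to 5. Nothing in hand bears on what lies behind the step.

The compounds shown leave open which part of dimethylcarbamoyl goes with the weaker reading: its carbonyl, the two methyl groups on its nitrogen, or simply the larger group at this carbon. An unsubstituted carboxamide, a methyl ester or a propoxy chain on the same carbon would begin to separate these readings, and a single step from one pair cannot show whether the same change would behave alike elsewhere on the core.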